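The compounds below may be only part of what the source reports. "The series", "measured", "known", "first", "only" and "open" are said of these compounds alone.

Working notes on the series.

Of the compounds shown here, three have been measured in an assay on CHO cells for displacement of a labelled ligand from adenosine receptor A3 (Homo sapiens), read by scintillation counting, with a stated time of 60 min, tested at 1 uM; on this read-out higher numbers stand for more inhibition at the one concentration tested (going by the name of the read-out) and lower numbers for less inhibition. Compound 1 `COc1ccc(-n2cc3nc(C)nc(NC(=O)Nc4ccccc4)c3n2)cc1` gives 1%, compound 2 `COc1ccc(-n2cc3nc(C)nc(NC(=O)NCc4ccccc4)c3n2)cc1` gives 6%, and compound 3 `Nc1nc(-c2ccccc2)nc2cn(-c3ccccc3)nc12` gives 48%. Compound 1 stands lowest of the three numbers: compound 2 is nearest, and the step of a number 5 percentage points higher from compound 1 to compound 2 (within the scatter) lies within the scatter, so no order between compound 1 and compound 2 can be claimed; compound 3 is furthest, with a number well beyond the scatter above compound 1.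

The next compound, compound 4 `COc1ccc(-n2cc3nc(C)nc(N)c3n2)cc1`, differs from compound 1 in one place: hydrogen in place of phenylcarbamoyl on a nitrogen on an aromatic ring. Within the data shown here, no measured step covers this change. Among the measured compounds shown here, the only measured step, a number 5 percentage points higher from compound 1 to compound 2 (within the scatter), exchanges groups on the other side of the phenylcarbamoyl and was within the scatter, so it says nothing about removing the phenylcarbamoyl altogether. Compound 3, which carries a hydrogen at the corresponding nitrogen, gives 48%, but it differs from compound 1 in several further places, so its number is only a loose hint that a compound without the phenylcarbamoyl may reach higher inhibition.

On that basis compound 4 is expected to rise relative to compound 1, estimated at 25% with a range of 3% to 60%; the expected step is a number 24 percentage points higher from compound 1 to compound 4 (beyond the scatter), uncertain in size.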

Compound 4, a percentage reported as inhibition, at one concentration (the size of the read-out at that concentration, not a potency): 38%
Estimate against measurement, compound 4: 13 percentage points below; measured number inside the range.
By their numbers in this assay, from the lowest: compounds 1 and 2 (each within the scatter of the next); then compounds 4 and 3 (each within the scatter of the next).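

In this assay the nitrogen on an aromatic ring now shows a single change that moves the number beyond the scatter: with hydrogen in place of phenylcarbamoyl, the result is a number 37 percentage points higher from compound 1 to compound 4 (beyond the scatter). The earlier change in this substituent, benzyl in place of phenyl on an amide-type nitrogen, stayed small as a number 5 percentage points higher from compound 1 to compound 2 (within the scatter), so exchanging the end of the group left the number within the scatter, while removing the whole group from the nitrogen gave a large step in the single-concentration read-out. No measured information on the compounds bears on why this step is so large.

Still open, from the compounds shown here alone, is whether the low numbers of compound 1 and compound 2 go with the whole carbamoyl unit or only with its terminal ring, a question that an acetyl or a methyl on the same nitrogen would address. Also open, going by these compounds, is whether the step holds when the methoxy is replaced by another group, such as an amine or a carboxylic acid, as both one-place steps here keep the methoxy fixed.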